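The source may hold more compounds than are shown below. What is called first, only, known or untested is meant among the compounds shown, and "the series" means these compounds.

Of the compounds shown here, two have so far been measured in a functional assay on NCI-H1975 cells (Homo sapiens) for inhibition, read by MTT assay, with a stated time of 72 h; on this read-out lower numbers stand for stronger inhibition and higher numbers for weaker inhibition. Compound 1, `O=C(CSc1nc(Nc2ccccc2)c2ccccc2n1)Nc1ccc(Cl)cc1`, gives 8040 nM in this assay. Compound 2, `C=CC(=O)Nc1cccc(NC(=O)CSc2nc(Nc3ccccc3Br)c3ccccc3n2)c1`, gives 19300 nM in this assay. Of these two numbers, compound 2 holds the higher one, and the gap to compound 1 lies beyond the usual scatter of repeated measurements. Among the measured compounds shown here, the two measured compounds differ in more than one place, so no single-change step can be drawn between them.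

Compound 3, `C=CC(=O)Nc1cccc(NC(=O)CSc2nc(Nc3ccc(Cl)cc3)c3ccccc3n2)c1`, has not yet been measured. It differs from compound 2 in one place: 4-chlorophenyl in place of 2-bromophenyl on a nitrogen on an aromatic ring. The group that enters is the same group that compound 1 carries on that nitrogen. Compound 3 is expected to come out somewhat lower than compound 2 because compound 1, carrying that same 4-chlorophenyl, gives 8040 nM. The expected step is a 1.8-fold lower number from compound 2 to compound 3 (0.24 log units; within the scatter), a modest move downward that may not clear the scatter. Compound 3 is therefore estimated at 11000 nM, with a likely range from 3500 nM to 35000 nM.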

Compound 3, half-maximal inhibitory concentration: 7580 nM
Beside the measured number, compound 3's estimate is 1.5-fold (0.16 log units) above it; the range from low to high includes it.
By their numbers in this assay, from the lowest: compounds 3 and 1 (each within the scatter of the next); then compound 2.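

In this assay, placing 4-chlorophenyl in place of 2-bromophenyl on a nitrogen on an aromatic ring gives a 2.5-fold lower number from compound 2 to compound 3 (0.41 log units; beyond the scatter). Among the compounds shown here, this is the first single-change step, and it shows that the number responds to the aryl group at this position, even though the step is modest and compound 3 still sits at 7580 nM. The data offer no explanation for the change in the number.

The halogen and its place on the ring change together in this step, so the two compounds cannot show whether the element, its location or both account for the difference. Also open, as far as these compounds go, is how this nitrogen would respond to a substituent of a different kind, such as a short alkyl chain in place of the aryl ring, or an amine or a carboxylic acid carried on that ring.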